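Swapping pyridin-3-yl for 1-hydroxycyclohexyl

The source may hold more compounds than are shown below. What is called first, only, known or untested is meant among the compounds shown, and "the series" means these compounds.

Of the compounds shown here, two that share most of their structure have been tested in a functional assay on MiaPaCa cells (Homo sapiens) for antiproliferative activity, read by sulforhodamine B assay, with a stated time of 48 h; a lower number here means a stronger inhibitor of growth, a higher number a weaker inhibitor of growth. Compound 1 `COc1ccc2cc(-c3cn(CCCN4C(=O)COc5ccccc54)nn3)ccc2c1` gives > 100000 nM, which is a limit of the assay and not a number. Among the measured compounds shown here, compound 2 `O=C1COc2ccccc2N1CCCn1cc(-c2cccnc2)nn1` gives 8200 nM, the only actual number so far, and so the sole firm reference point. Compound 3 `O=C1COc2ccccc2N1CCCn1cc(C2(O)CCCCC2)nn1` has not yet been measured. It differs from compound 2 in one place: 1-hydroxycyclohexyl in place of pyridin-3-yl on an aromatic carbon. A 1-hydroxycyclohexyl group takes the place of pyridin-3-yl on an aromatic carbon of the five-membered aromatic ring with 3 nitrogen. For the measured compounds named here, no measured step shows what this exchange does, so any forecast is loose. A moderate loss of growth inhibition in this assay is expected, an estimated step of a 2.4-fold higher number from compound 2 to compound 3 (0.39 log units; beyond the scatter). For compound 3 the expected value is 20000 nM, within an estimated range of 5000 nM to 100000 nM.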

Compound 3, concentration for 50% growth inhibition: 2500 nM
Beside the measured number, compound 3's estimate is 8.0-fold (0.90 log units) above it, outside the stated range (below it).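

In this assay an aromatic ring is not needed on the five-membered aromatic ring with 3 nitrogen: exchanging pyridin-3-yl for 1-hydroxycyclohexyl gives a 3.3-fold lower number from compound 2 to compound 3 (0.52 log units; beyond the scatter). Among the compounds shown here, this is the first measured step at this place, and it shows that a six-membered non-aromatic ring of carbon only, bearing a hydroxyl group, keeps growth inhibition and modestly improves it. Nothing measured here explains why the number falls.

The compounds shown leave open whether the hydroxyl group or the non-aromatic ring matters more: a plain cyclohexyl group, or 1-aminocyclohexyl with an amine in place of the hydroxyl, would separate the two. Also open, on these data alone, is whether the ring itself is needed, which 2-hydroxypropan-2-yl, an open-chain group bearing the same hydroxyl, would test.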